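The source may hold more compounds than are shown below. What is called first, only, known or untested is meant among the compounds shown, and "the series" means these compounds.

Measured so far:
- compound 1, `CCC(=O)N1N=C(c2ccc(C)cc2)CC1c1cn(-c2ccccc2)nc1-c1ccc(Cl)c(Cl)c1`: 61.1%
- compound 2, `Fc1ccc(C2=NN(c3ccccc3)C(c3cn(-c4ccccc4)nc3-c3ccc(Cl)c(Cl)c3)C2)cc1`: 55.7%

Both were tested in a functional assay on the whole organism (strain Wistar) for inhibition, with Rattus norvegicus as the target, read by paw edema, with stated times of 30 min and 60 min, at a dose of 50 mg/kg by the oral route; a higher number here means more inhibition at the dose given (going by the name of the read-out), a lower number less inhibition. Compound 1 reaches 61.1% there, and compound 2 gives 55.7%. The two numbers lie within the scatter of each other, so compound 2 cannot be called weaker than compound 1 on this evidence.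

Compound 3, `CCC(=O)N1N=C(c2ccc(F)cc2)CC1c1cn(-c2ccccc2)nc1-c1ccc(Cl)c(Cl)c1`, has not yet been measured. It differs from compound 2 in one place: propanoyl in place of phenyl on an amine nitrogen in a ring.

Among the compounds with values here, no measured pair shows what such an exchange does here, so there is nothing in the data to say which way it moves the read-out. The expectation is therefore a step from compound 2 to compound 3 of no size beyond the scatter, a number 2.3 percentage points higher from compound 2 to compound 3 (within the scatter). On that basis compound 3 is estimated at 58% in this assay, with a likely range from 42% to 74%.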

Compound 3, a percentage reported as inhibition, in the whole organism at one dose (the size of the read-out at that dose, not a potency): 63.4%
The estimate for compound 3 lay 5.4 percentage points below the measured number; low and high end bracket the measured number.
By their numbers in this assay, from the lowest: compounds 2, 1 and 3 (each within the scatter of the next).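

In this assay, within the data shown here, putting propanoyl in place of phenyl on the amine nitrogen in the ring gives a number 7.7 percentage points higher from compound 2 to compound 3 (within the scatter) and is the first measured exchange at this position: an aromatic ring and an open chain carrying a carbonyl cannot be told apart there by this read-out. Fluoro in place of methyl on an aromatic carbon gives a number 2.3 percentage points higher from compound 1 to compound 3 (within the scatter) and so cannot be told apart either, which means that neither exchange yet marks a group as better or worse. No separate measurement bears on these results.

The compounds shown leave open whether acetyl, a longer chain such as butanoyl, or a plain hydrogen on that nitrogen would move the number beyond the scatter. The same question stands for chloro or methoxy in place of the fluoro.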